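Methoxy for methylpyrazolyl on the fused-ring imidazole core

The source may report more compounds than this note shows. Statements on the series, on what has been measured and on what is new or still open speak of the compounds shown alone.

Measured so far:
- compound 1 `Cc1n[nH]cc1-c1cccc2c1CCC2c1ncc[nH]1`: in a functional assay on CHO cells for agonist activity at Alpha-1A adrenergic receptor (Homo sapiens), read by FLIPR and calcium flux (on this read-out higher numbers stand for larger maximal responses and lower numbers for smaller maximal responses), compound 1 gives 91%
- compound 2 `CS(=O)(=O)Nc1cccc2c1CCCC2c1ncc[nH]1`: compound 2 gives 47%; 79%; 79% (3 entries)
- compound 3 `CS(=O)(=O)Nc1c(Cl)ccc2c1CCCC2c1ncc[nH]1`: compound 3 gives 61%

Compound 1 stands highest of the two single numbers in this assay; the nearest is compound 3, whose number lies a step below that is beyond the scatter. Compound 2 carries no single number: its entries, (the several entries of compound 2 in this assay, 47%; 79%; 79% (3 entries)), spread widely, so it is taken only as a further point lying under compound 1. Among the measured compounds shown here, no pair of measured compounds differs in one place, so no measured step is available to guide the next change.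

Compound 4 `COc1cccc2c1CCC2c1ncc[nH]1` differs from compound 1 as follows: methoxy in place of 3-methyl-1H-pyrazol-4-yl on an aromatic carbon. The largest response reached for compound 4 is expected to fall rather than rise, and the step of a number 26 percentage points lower from compound 1 to compound 4 (beyond the scatter) is expected to go beyond the scatter, because compound 3 gives 61% and compound 2 sits under compound 1 as well. For compound 4 the value expected is 65%, with a range from 40% to 90%.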

Compound 4, largest response reached (Emax), in percent of the reference or control that the assay uses: 65%
Beside the measured number, compound 4's estimate shows no gap at the digits printed; the measured number falls inside the stated range.
By their numbers in this assay, from the lowest: compounds 3 and 4 (each within the scatter of the next); then compound 1.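

Among the compounds shown here, this position responds to the group it carries: in this assay, methoxy in place of 3-methyl-1H-pyrazol-4-yl on an aromatic carbon gives a number 26 percentage points lower from compound 1 to compound 4 (beyond the scatter), the only step so far that differs in one place. The change removes one five-membered aromatic ring and a hydrogen-bond donor, yet a substantial maximal response remains, with compound 4 at 65%. None of the data shown accounts for the fall.

This single step does not separate the contribution of the ring from that of the donor, and the heavy-atom count changes along with both. On these data alone, how an amine, a carboxylic acid or a longer chain such as ethoxy on this aromatic carbon would shift the maximal response remains open.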